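Amine swap on the propoxy chain of a chromone

The compounds below may be only part of what the source reports. "The series", "measured", "known", "first", "only" and "open" are said of these compounds alone.

Of the compounds shown here, three sharing one core have been measured in a functional assay on HCT-116 cells (Homo sapiens) for antiproliferative activity, read by MTT assay, with a stated time of 48 h; a higher number here means a weaker inhibitor, a lower number a stronger inhibitor. Compound 1 `CCN(CC)CCCOc1cc2oc(-c3ccccc3)cc(=O)c2c(O)c1OC` gives 23400 nM. Compound 2 `COc1c(OCCCN2CCCCC2)cc2oc(-c3ccccc3)cc(=O)c2c1O` gives 22100 nM. Compound 3 `COc1c(OCCCN2CCN(C)CC2)cc2oc(-c3ccccc3)cc(=O)c2c1O` gives 42500 nM. Compound 2 stands with the other two close around it: the step of a 1.1-fold lower number from compound 1 to compound 2 (0.02 log units; within the scatter) and the step of a 1.9-fold higher number from compound 2 to compound 3 (0.28 log units; within the scatter) are both within the scatter, as is a 1.8-fold higher number from compound 1 to compound 3 (0.26 log units; within the scatter). Exchanging one amine for another on this chain has so far moved nothing beyond the scatter.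

Compound 4 `COc1c(OCCCCN2CCCC2)cc2oc(-c3ccccc3)cc(=O)c2c1O` is not yet measured. It differs from compound 2 by (pyrrolidin-1-yl)methyl in place of piperidin-1-yl on a saturated chain carbon, three bonds along the chain from an oxygen on an aromatic ring. Going by the values given here, the steps that bear on it are the amine exchanges already seen, a 1.1-fold lower number from compound 1 to compound 2 (0.02 log units; within the scatter) and a 1.9-fold higher number from compound 2 to compound 3 (0.28 log units; within the scatter), each within the scatter. He therefore expects no step beyond the scatter in this assay, that is a 1.0-fold lower number from compound 2 to compound 4 (0.00 log units; within the scatter) as a rough estimate. Compound 4 is estimated at 22000 nM, within a range from 10000 nM to 48000 nM.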

Compound 4, half-maximal inhibitory concentration: 1400 nM
The estimate for compound 4 lay 16-fold (1.20 log units) above the measured number, outside the stated range (below it).
By their numbers in this assay, from the lowest: compound 4; then compounds 2, 1 and 3 (each within the scatter of the next).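

In this assay, this position proved able to carry a large change, which the amine exchanges on the propoxy chain had not shown: there is a 16-fold lower number from compound 2 to compound 4 (1.20 log units; beyond the scatter) and also a 17-fold lower number from compound 1 to compound 4 (1.22 log units; beyond the scatter) as well as a 30-fold lower number from compound 3 to compound 4 (1.48 log units; beyond the scatter), which places compound 4 as the strongest of the four. Unlike those exchanges, this change replaces 3-(piperidin-1-yl)propyl with 4-(pyrrolidin-1-yl)butyl, so a five-membered ring and a longer chain enter together. Nothing given here accounts for the size of the step.

The compounds shown leave open whether the ring, the chain or only their combination goes with the lower number, a question that 3-(pyrrolidin-1-yl)propyl and 4-(piperidin-1-yl)butyl on the shared core would address. They also leave open how a 5-(pyrrolidin-1-yl)pentyl chain would read.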